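This account rests on a few compounds, and the source may have more. Where it says the series, first, only, none or still open, it means among the compounds named here.

Three amides that share one core have been measured. Compound 1 `Cc1cc(C(=O)NCN2CCC(c3cccc[n+]3[O-])CC2)ccc1F` gives 50 nM in a functional assay on HEK293 cells for agonist activity at D(4) dopamine receptor (Homo sapiens), read by FLIPR (on this read-out higher numbers stand for an effect only at larger amounts of compound and lower numbers for an effect already at smaller amounts), and compound 2 `O=C(NCN1CCC(c2cccc[n+]2[O-])CC1)c1ccc(F)c(Cl)c1` gives 63 nM in this assay. Compound 3 `Cc1ccc(C(=O)NCN2CCC(c3cccc[n+]3[O-])CC2)cc1C` gives 38 nM in this assay, and its number sits alongside those of the other two: the steps of a 1.3-fold lower number from compound 1 to compound 3 (0.12 log units; within the scatter) and a 1.7-fold lower number from compound 2 to compound 3 (0.22 log units; within the scatter) both stay within the usual scatter, so no ordering among the three can be claimed.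

Compound 4 `O=C(NCN1CCC(c2cccc[n+]2[O-])CC1)c1cc(Cl)cc(Cl)c1` has not been measured. It differs from compound 3 in one place: 3,5-dichlorophenyl in place of 3,4-dimethylphenyl on a carbonyl carbon. The measured steps that bear on this are a 1.3-fold higher number from compound 1 to compound 2 (0.10 log units; within the scatter), where a chlorine replaces a methyl on the aromatic ring, and a 1.7-fold lower number from compound 2 to compound 3 (0.22 log units; within the scatter), where two methyl groups replace a chloro and a fluoro. Neither moved beyond the scatter. On that basis the expectation for compound 4 in this assay is a step of a 1.4-fold higher number from compound 3 to compound 4 (0.16 log units; within the scatter), that is, no change beyond the scatter. Compound 4 is therefore expected to give about 55 nM in this assay, within a range from 22 nM to 140 nM.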

Compound 4, half-maximal effective concentration: 45 nM
Beside the measured number, compound 4's estimate is 1.2-fold (0.09 log units) above it; the measured number falls inside the stated range.
By their numbers in this assay, from the lowest: compounds 3, 4, 1 and 2 (each within the scatter of the next).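

Placing 3,5-dichlorophenyl on a carbonyl carbon in this assay gives a 1.2-fold higher number from compound 3 to compound 4 (0.07 log units; within the scatter) and so stays within the scatter of the 3,4-dimethylphenyl amide. The comparisons with the other two amides read a 1.4-fold lower number from compound 2 to compound 4 (0.15 log units; within the scatter) and a 1.1-fold lower number from compound 1 to compound 4 (0.05 log units; within the scatter) and are also within the scatter. Compound 4 keeps neither methyl group of compound 3 and carries two chlorine atoms, so among these four amides, this place accepts all four substituted phenyl groups shown with no step beyond the scatter.

Nothing available gives a reason for this flat picture. On these data alone, it also remains open whether a phenyl group bearing an amine or a carboxylic acid, or a longer chain in place of the phenyl group, would keep the number in the same range.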